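Swapping the anilino substituent on a shared core

This account rests on a few compounds, and the source may have more. Where it says the series, first, only, none or still open, it means among the compounds named here.

Measured compounds:
compound 1 `Nc1ccccc1NC(=O)/C=C/c1ccc(COCNc2nc(Nc3cccc(Cl)c3)c3ncn(C4CCCC4)c3n2)cc1`: 14.8%
compound 2 `Nc1ccccc1NC(=O)c1ccc(COCNc2nc(Nc3ccccc3)c3ncn(C4CCCC4)c3n2)cc1`: 66.9%
compound 3 `Nc1ccccc1NC(=O)c1ccc(COCNc2nc(Nc3cccc(Cl)c3)c3ncn(C4CCCC4)c3n2)cc1`: 63.2%

All three were tested in a functional assay on HepG2 cells (Homo sapiens) for antiproliferative activity, read by CCK-8 assay, with a stated time of 72 h, tested at 8 uM; a lower number here means a weaker effect, a higher number a stronger effect of the compound at the concentration tested. Among them, compound 3 stands second highest of the three numbers. Its nearest neighbour is compound 2, which gives 66.9%, a gap described by a number 3.7 percentage points lower from compound 2 to compound 3 (within the scatter). Its furthest neighbour is compound 1, which gives 14.8%; the step of a number 48.4 percentage points higher from compound 1 to compound 3 (beyond the scatter) shows how much the read-out rises when the linker to the amide is shortened.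

Compound 4 `Nc1ccccc1NC(=O)c1ccc(COCNc2nc(Nc3ccc(-c4ccccc4)cc3)c3ncn(C4CCCC4)c3n2)cc1` has not yet been measured. It differs from compound 3 in one place: 4-phenylphenyl in place of 3-chlorophenyl on a nitrogen on an aromatic ring. Among the compounds with values here, no measured pair shows a change of this kind; the only step at the same position, a number 3.7 percentage points lower from compound 2 to compound 3 (within the scatter), exchanges chloro for hydrogen and lies within the scatter. Within the data shown here, with no direct precedent, the step into compound 4 is expected to be modest, and no direction beyond the scatter is strongly indicated, though a drop is considered somewhat more likely than a gain. The step expected is a number 8.2 percentage points lower from compound 3 to compound 4 (within the scatter). Compound 4 is therefore estimated to give 55%, with a range from 30% to 75%.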

Compound 4, a percentage reported as inhibition, at one concentration (the size of the read-out at that concentration, not a potency): 36.2%
For compound 4 the middle estimate is 18.8 percentage points above the measured one; measured number inside the range.
By their numbers in this assay, from the lowest: compound 1; then compound 4; then compounds 3 and 2 (each within the scatter of the next).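

Within the data shown here, the change from 3-chlorophenyl to 4-phenylphenyl on the nitrogen, which brings 12 heavy atoms in place of 7 and a second six-membered aromatic ring of carbon only, gives the first step at this position that clears the scatter in this assay, with a number 27 percentage points lower from compound 3 to compound 4 (beyond the scatter) as its size. Read from the compound with the plain phenyl on that nitrogen, adding a further phenyl gives a number 30.7 percentage points lower from compound 2 to compound 4 (beyond the scatter) as its result, whereas adding a chloro gave a number 3.7 percentage points lower from compound 2 to compound 3 (within the scatter) as its result, so this position does not accept every addition without a change in the read-out. Nothing among the data given accounts for the drop.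

The compounds shown do not separate the effect of the second aromatic ring from that of its place on the first, and they leave open whether a smaller group such as methyl or methoxy, or an amine or a carboxylic acid, would hold the read-out or lower it. With one cell line at one concentration, they show only a stronger or weaker effect at that concentration and leave open how these compounds compare at any other.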